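A Ring Swap on a Small Aromatase Inhibitor

This account rests on a few compounds, and the source may have more. Where it says the series, first, only, none or still open, it means among the compounds named here.

Compound 2 `CCCCCCc1cn(Cc2ccccc2)nn1` is one of two compounds that have been tested in an assay on isolated protein for inhibition of Aromatase (Homo sapiens), read by fluorescence and colorimetric assay, with a stated time of 30 min; on this read-out lower numbers stand for stronger inhibition and higher numbers for weaker inhibition. In this assay compound 2 gives 7470 nM. The other compound, compound 1 `c1ccc(C(c2ccccc2)n2cc(C3CCCCC3)nn2)cc1`, gives 13700 nM in this assay. Compound 2 thus stands at one end of the two numbers measured, but the gap to compound 1 lies within the usual scatter of repeated measurements, so the two compounds cannot be told apart on this read-out.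

Compound 3 `c1ccc(Cn2cc(C3CCCCC3)nn2)cc1` has not yet been measured. It differs from compound 2 in a single place: cyclohexyl in place of hexyl on an aromatic carbon. For the measured compounds named here, no pair of measured compounds shows this exact change, so there is no measured step to lean on. Compound 1 also carries a cyclohexyl group, and its number sits close to that of compound 2. For compound 3 the expected step in this assay is a 1.1-fold higher number from compound 2 to compound 3 (0.03 log units; within the scatter), meaning no change beyond the scatter. Compound 3 is therefore estimated to give about 8000 nM in this assay, with a range from 3000 nM to 25000 nM.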

Compound 3, half-maximal inhibitory concentration: 7980 nM
For compound 3 the middle estimate is 1.0-fold (0.00 log units) above the measured one, within the range that was stated.
By their numbers in this assay, from the lowest: compounds 2, 3 and 1 (each within the scatter of the next).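

Putting cyclohexyl in place of hexyl on this aromatic carbon swaps an open chain for a ring of the same six carbons, and the step is a 1.1-fold higher number from compound 2 to compound 3 (0.03 log units; within the scatter) in this assay. This direct comparison at the position therefore shows that closing the chain into a ring does not move the number beyond the scatter. Compound 3 also gives a second single-place comparison, at the saturated chain carbon bound to an aromatic carbon and an aromatic nitrogen: hydrogen in place of phenyl there gives a 1.7-fold lower number from compound 1 to compound 3 (0.23 log units; within the scatter), so removing that phenyl does not move the number beyond the scatter either.

No measurement at hand bears on why these two changes leave the number within the scatter. Still open, from the compounds shown here alone, is whether a different kind of group on the same aromatic carbon, such as an amine, a carboxylic acid or a longer chain, would shift the number by more than the scatter.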